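This account rests on a few compounds, and the source may have more. Where it says the series, first, only, none or still open, it means among the compounds named here.

Measured compounds:
compound 1, `N=C(N)c1ccc(-c2ccc(-c3nc4cc(C(=N)N)ccc4[nH]3)o2)cc1`, gives 43200 nM in a functional assay on B16 cells (Mus musculus), with a stated time of 72 h; a lower number here means a stronger inhibitor, a higher number a weaker inhibitor.
compound 2, `CN(C)CCC/N=C(\N)c1ccc(-c2ccc(-c3nc4cc(/C(N)=N/CCCN(C)C)ccc4[nH]3)o2)cc1`, gives > 100000 nM in this assay.

Among the measured compounds shown here, compound 1 stands as the only number in this assay; the other entry is not a number. For compound 2 the entry is a limit of this assay, (the limit of > 100000 nM in this assay, at which 1 of the 2 values shown sits), so nothing more can be said of it than that it lies at the limit. For the measured compounds named here, there is thus no measured step between two numbers to lean on.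

Compound 3, `N=C(N)c1ccc2[nH]c(-c3ccc(-c4ccc(N)cc4)o3)nc2c1`, is not yet measured. It differs from compound 1 by one nitrogen atom in place of a group of 3 heavy atoms (1 carbon, 2 nitrogen; no ring), on an aromatic carbon, on an aromatic carbon of a six-membered aromatic ring of carbon only, para to a large group.

Going by the values given here, with no measured step to anchor it, the expectation for this change rests on compound 1 alone. A step of about a 1.4-fold higher number from compound 1 to compound 3 (0.14 log units; within the scatter) is expected, pointing towards weaker inhibition but not beyond the usual scatter. Compound 3 is accordingly estimated at 60000 nM, within a range from 15000 nM to 200000 nM.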

Compound 3, half-maximal inhibitory concentration: > 100000 nM
Compound 3 gave a limit, no number (the forecaster's own chance of this, stated with the estimate: 30%); at least 1.6-fold (0.22 log units) between middle value and limit.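

In this assay, putting amino in place of the group of 3 heavy atoms on this aromatic carbon, para to a large group, gives an at least 2.3-fold higher number from compound 1 to compound 3 (0.36 log units; beyond the scatter). Among the compounds shown here, this is the first single change that can be read in the set, and it shows that this position does not tolerate the swap without a loss of inhibition beyond the scatter, with the printed step only setting the least that the change costs. Compound 3 gives > 100000 nM, which is a limit of the assay and not a number, and with it the limit now holds most of the values in the set: the limit of > 100000 nM in this assay, at which 2 of the 3 values shown sit.

On these data alone, how far compound 3 really lies from compound 1 stays open, as does whether the loss comes from removing the group of 3 heavy atoms or from the presence of amino in its place. A hydroxyl, a carboxylic acid or an aminomethyl group at this position could separate these two readings, and only a value that falls below the limit would give the size of the step.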